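Methylsulfonyl in place of (phenoxymethyl)carbonyl in compound 3

The source may report more compounds than this note shows. Statements on the series, on what has been measured and on what is new or still open speak of the compounds shown alone.

- compound 1 `COc1ccc(-c2scc3c(N4CC[C@@H](NC(C)=O)C4)nc(C)nc23)cc1OC` gives > 95% as a limit
- compound 2 `CC(=O)N[C@@H]1CCN(c2cc(C)nn3c(-c4ccc5cc[nH]c5c4)c(C)nc23)C1` gives > 95% as a limit
- compound 3 `COc1ccc(-c2c(C)nc3c(N4CC[C@@H](NC(=O)COc5ccccc5)C4)cc(C)nn23)cc1OC` gives > 95% as a limit

In an ADME assay on microsomes from liver (Mus musculus) for metabolic stability, read by LC-MS, with NADPH named in the record, with a stated time of 60 min, tested at 1 uM, in the absence of a further agent (on this read-out lower numbers stand for a less stable compound and higher numbers for a more stable compound), compound 3 gives > 95% as a limit and not a number. The picture so far is the limit of > 95% in this assay, at which 3 of the 3 values shown sit, with no exact value among them. Compound 4 `COc1ccc(-c2c(C)nc3c(N4CC[C@@H](NS(C)(=O)=O)C4)cc(C)nn23)cc1OC` carries methylsulfonyl in place of (phenoxymethyl)carbonyl on an amine nitrogen, and the full count of that difference reads methylsulfonyl in place of (phenoxymethyl)carbonyl on an amine nitrogen in its own terms. Within the data shown here, no measured pair shows this kind of change, so the forecast leans on compound 3 alone, whose > 95% stands as a limit. The expected a number at least 3 percentage points lower from compound 3 to compound 4 (that floor lies within the scatter) in this assay is no shift beyond the scatter. For compound 4 the estimate is 92% with an expected range from 78% to 100% in the same read-out.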

Compound 4, percent of the compound remaining: > 95%
Compound 4: a limit, no number (the forecaster's own chance of this, stated with the estimate: 60%); middle value at least 3 percentage points from the limit.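

In this assay compound 4 gives > 95%, a limit and not a number. Among these compounds, compound 3 also stands at a limit, so no step between the two can be read. How far the compounds shown differ in stability stays open, as all share one ceiling: the limit of > 95% in this assay, at which 4 of the 4 values shown sit.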